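Trimming a fused ring down to a single pyrazole

The source may hold more compounds than are shown below. What is called first, only, known or untested is meant among the compounds shown, and "the series" means these compounds.

Three compounds share one core and differ only in the aromatic group attached to the chlorinated ring. Compound 1 `Cc1nc(C(F)(F)F)ccc1C(=O)Nc1ccc(Cl)c(-c2cc3ccccc3[nH]2)c1` gives 500 nM in an assay on C3H 10T1/2 cells for inhibition of Sonic hedgehog protein (Mus musculus), read by a luciferase reporter; a lower number here means a stronger inhibitor, a higher number a weaker inhibitor. Compound 2 `Cc1nc(C(F)(F)F)ccc1C(=O)Nc1ccc(Cl)c(-c2nc3ccccc3n2C)c1` gives 9 nM in this assay, the lowest number of the three; compound 3 `Cc1nc(C(F)(F)F)ccc1C(=O)Nc1ccc(Cl)c(-c2cn3ccsc3n2)c1` gives 200 nM. The two measured steps are large: a 56-fold lower number from compound 1 to compound 2 (1.74 log units; beyond the scatter) and a 22-fold higher number from compound 2 to compound 3 (1.35 log units; beyond the scatter), so the group in this position matters a great deal.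

Compound 4 `Cc1nc(C(F)(F)F)ccc1C(=O)Nc1ccc(Cl)c(-c2ccn(C)n2)c1` keeps everything of compound 2 except this group: 1-methyl-1H-pyrazol-3-yl in place of 1-methyl-1H-benzimidazol-2-yl on an aromatic carbon. The 1-methyl-1H-pyrazol-3-yl group keeps the two hydrogen-bond acceptors but loses the six-membered aromatic ring of carbon only. Among the measured compounds shown here, the only guide is compound 3, where a different, smaller group in place of 1-methyl-1H-benzimidazol-2-yl cost a 22-fold higher number from compound 2 to compound 3 (1.35 log units; beyond the scatter). A loss of similar order is therefore expected, an 11-fold higher number from compound 2 to compound 4 (1.05 log units; beyond the scatter), with wide uncertainty. Compound 4 is estimated at 100 nM, between 25 nM and 500 nM.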

Compound 4, half-maximal inhibitory concentration: 550 nM
The estimate for compound 4 lay 5.5-fold (0.74 log units) below the measured number; the measured number lies above the stated range.
By their numbers in this assay, from the lowest: compound 2; then compound 3; then compounds 1 and 4 (each within the scatter of the next).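

Taking away the six-membered aromatic ring of carbon only, while the five-membered ring, its methyl and the hydrogen-bond acceptors stay, gives a 61-fold higher number from compound 2 to compound 4 (1.79 log units; beyond the scatter) in this assay, so the count of acceptors alone does not secure the low number of compound 2. The smaller group is also set against the other two: there is a 2.8-fold higher number from compound 3 to compound 4 (0.44 log units; beyond the scatter), a modest step, and a 1.1-fold higher number from compound 1 to compound 4 (0.04 log units; within the scatter). Compound 1 carries a six-membered aromatic ring of carbon only and compound 4 does not, yet their numbers cannot be told apart, so that ring alone does not secure a low number either. Nothing measured here explains why the group of compound 2 stands apart.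

Still open, from the compounds shown here alone, is whether a 1H-benzimidazol-2-yl group with hydrogen in place of the methyl would keep the low number. Also open, going by these compounds, is whether an amine or a phenyl ring added to the pyrazole would recover any of the loss.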